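The compounds below may be only part of what the source reports. "The series", "measured", "known", "first", "only" and "open" are said of these compounds alone.

Compound 1, `NC(=O)c1cn(COCCO)c2ncnc(N)c12`, gives in an ADME assay on BSC-1 cells (Cercopithecidae) for cytotoxicity (on this read-out lower numbers stand for stronger inhibition and higher numbers for weaker inhibition), only a limit, > 100000 nM.
Compound 2, `NC(=NO)c1cn(COCCO)c2ncnc(N)c12`, gives in this assay only a limit, > 100000 nM.
Compound 3, `NC(=S)c1cn(COCCO)c2ncnc(N)c12`, gives in this assay only a limit, > 100000 nM.

All three measured compounds share one core and differ only in the group that sits on one aromatic carbon. None of them yields a number: each sits at the limit of > 100000 nM in this assay, at which 3 of the 3 values shown sit, so compound 3 cannot be placed above or below its two companions. The steps among them, a step that the two limits leave unreadable from compound 1 to compound 2, a step that the two limits leave unreadable from compound 1 to compound 3 and a step that the two limits leave unreadable from compound 2 to compound 3, are therefore of unknown size.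

Compound 4, `NNC(=O)c1cn(COCCO)c2ncnc(N)c12`, differs from compound 3 by a group of 4 heavy atoms (1 carbon, 2 nitrogen, 1 oxygen; no ring) in place of a group of 3 heavy atoms (1 carbon, 1 nitrogen, 1 sulfur; no ring), on an aromatic carbon. Every measured step changes this same group, and each of them ran from one limit to another. Among the measured compounds shown here, no measured step in this assay therefore has a readable size. The expectation for compound 4 is therefore that it behaves like its companions, with a step of a number no higher from compound 3 to compound 4 (the limit leaves the size open) from compound 3 that is most likely not readable. The estimate for compound 4 in this assay is 100000 nM, with a range from 30000 nM to 300000 nM.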

Compound 4, half-maximal inhibitory concentration: > 100000 nM
Compound 4: no number, only a limit; the forecaster's own chance of this, stated with the estimate: 85%; the middle value lies on the limit itself.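

Compound 4 adds no readable step: its distance from compound 1, compound 2 and compound 3 cannot be read, because all four results are limits rather than numbers: the limit of > 100000 nM in this assay, at which 4 of the 4 values shown sit. The compounds shown leave open whether changing the group on the aromatic carbon alters the read-out in this assay at all.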